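This account rests on a few compounds, and the source may have more. Where it says the series, first, only, none or still open, it means among the compounds named here.

Measured so far in a functional assay on MCF7 cells (Homo sapiens) for cytotoxicity, read by sulforhodamine B assay, with a stated time of 48 h; a lower number here means a stronger inhibitor of growth, a higher number a weaker inhibitor of growth:
Compound 1 `Cc1nn(-c2ccccc2)c(Oc2ccc(-c3nc4cc(C(=O)O)ccc4[nH]3)cc2)c1/C=N/NC(N)=S`: 18100 nM
Compound 2 `Cc1nn(-c2ccccc2)c(Oc2ccc(-c3nc4cc(C(N)=O)ccc4[nH]3)cc2)c1/C=N/Nc1ccc([N+](=O)[O-])cc1`: 8500 nM

Of these two, compound 2 has the lower number, which makes it the stronger inhibitor of growth, and its gap to compound 1 lies beyond the usual scatter of repeated measurements. The two compounds differ in more than one place, so that gap cannot be assigned to any single change.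

Compound 3 `Cc1nn(-c2ccccc2)c(Oc2ccc(-c3nc4cc(C(N)=O)ccc4[nH]3)cc2)c1/C=N/NC(N)=S` keeps the rest of compound 2 and changes one group: a group of 3 heavy atoms (1 carbon, 1 nitrogen, 1 sulfur; no ring) in place of a group of 9 heavy atoms (6 carbon, 1 nitrogen, 2 oxygen; one six-membered aromatic ring of carbon only), on an amine nitrogen. The 4-nitrophenyl leaves the amine nitrogen, and a small group without a ring takes its place.

Among the compounds with values here, no measured pair shows the effect of this swap alone in this assay. Compound 1, at 18100 nM, already carries the incoming group, but it differs from compound 3 elsewhere, so it is only a loose guide. The expected 1.3-fold higher number from compound 2 to compound 3 (0.11 log units; within the scatter) is small, towards a higher number, and may not clear the scatter. Compound 3 is estimated at 11000 nM, with an expected range of 4000 nM to 30000 nM.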

Compound 3, concentration for 50% growth inhibition: 9600 nM
Compound 3: middle estimate off by 1.1-fold (0.06 log units), on the high side, and the stated range covers the measured number.
By their numbers in this assay, from the lowest: compounds 2, 3 and 1 (each within the scatter of the next, the first and the last beyond it).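

In this assay, putting the small ring-free group on the amine nitrogen in place of 4-nitrophenyl gives a 1.1-fold higher number from compound 2 to compound 3 (0.05 log units; within the scatter), so this assay does not separate the two groups, even though one carries an aromatic ring and the other has none. Within the data shown here, the new compound also provides the first single-place comparison at the other end of the molecule: amino in place of hydroxy on a carbonyl carbon gives a 1.9-fold lower number from compound 1 to compound 3 (0.28 log units; within the scatter), which likewise stays within the scatter, so neither change alone clearly alters the read-out. Nothing available here explains either result.

With only two groups shown on the amine nitrogen, it remains open whether the position is as tolerant for others, such as a plain phenyl or a methyl group. On the carbonyl carbon, a methoxy or a methylamino group would test whether the numbers stay as close as they do for amino and hydroxy.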